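From Methyl to Ethyl on a Thioether-Linked Benzamide

The source may report more compounds than this note shows. Statements on the series, on what has been measured and on what is new or still open speak of the compounds shown alone.

Four related compounds share an aminophenyl amide joined through a thioether to a second aromatic ring. Compound 1 `Nc1ccccc1NC(=O)/C=C/c1ccc(CSc2ccc(F)cc2)cc1` carries a vinyl spacer before the amide, and in a functional assay on HeLa cells (Homo sapiens) for antiproliferative activity, read by CCK-8 assay, with a stated time of 72 h (a higher number here means a weaker inhibitor, a lower number a stronger inhibitor), compound 1 gives "not determined" (no result reported). Compound 3 `CC(C)(C)c1ccc(SCc2ccc(/C=C/C(=O)Nc3ccccc3N)cc2)cc1` carries the same spacer, and in this assay compound 3 gives "not determined" (no result reported). For the measured compounds named here, compound 2 `Cc1ccc(SCc2ccc(C(=O)Nc3ccccc3N)cc2)cc1` lacks that spacer and is the only member with a number: in this assay compound 2 gives 4250 nM, which is therefore the sole reference point, with no step to another measured compound available for comparison.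

Compound 4 `CCc1ccc(SCc2ccc(C(=O)Nc3ccccc3N)cc2)cc1` is the compound still to be measured. It differs from compound 2 by one change: methyl in place of hydrogen on a saturated chain carbon bound to an aromatic carbon. Put another way, the 4-methylphenyl group becomes a 4-ethylphenyl group. Going by the values given here, with only a single measured value and no step between measured compounds to learn from, the step from compound 2 to compound 4 is expected to be small, in no clear direction, and likely within the scatter, as a 1.1-fold lower number from compound 2 to compound 4 (0.03 log units; within the scatter) expresses. On that basis compound 4 is estimated at 4000 nM in this assay, with a range from 1500 nM to 10000 nM.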

Compound 4, half-maximal inhibitory concentration: 3800 nM
Estimate against measurement, compound 4: 1.1-fold (0.02 log units) above; the range from low to high includes it.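

Moving from 4-methylphenyl to 4-ethylphenyl in this assay gives a 1.1-fold lower number from compound 2 to compound 4 (0.05 log units; within the scatter) and provides the first readable step in this series. At this position, on a saturated chain carbon bound to an aromatic carbon, the added methyl leaves compound 2 and compound 4 indistinguishable in this measurement, so this small extension of the chain is tolerated without a detectable loss or gain. No measurement shown bears on why the two compounds read alike.

From the compounds shown here alone, whether a longer chain such as butyl, or an amine or a carboxylic acid at the same place, would also leave the number within the scatter remains open. Compound 1 and compound 3 have no number, so the vinyl spacer's contribution cannot be read.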